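Methyl to phenylsulfonyl on the ring amine nitrogen

The source may hold more compounds than are shown below. What is called first, only, known or untested is meant among the compounds shown, and "the series" means these compounds.

In a functional assay on QGY-7703 cells (Homo sapiens) for cytotoxicity, read by MTT assay, with a stated time of 24 h (a higher number here means a weaker inhibitor, a lower number a stronger inhibitor), compound 1 `CN1C/C(=C\c2cccnc2)C(=O)/C(=C/c2ccccc2C(F)(F)F)C1` gives 2910 nM and stands within the scatter of compound 2 `CN1C/C(=C\c2ccncc2)C(=O)/C(=C/c2ccccc2C(F)(F)F)C1` at 4500 nM on the same measure. Compound 3 `N#Cc1ccc(S(=O)(=O)N2C/C(=C\c3ccncc3)C(=O)/C(=C/c3ccccc3F)C2)cc1` gives 8500 nM as a number beyond the scatter from that of compound 1. Compound 4 `O=C1/C(=C/c2cccnc2)CN(S(=O)(=O)c2ccccc2)C/C1=C\c1ccccc1C(F)(F)F` carries phenylsulfonyl in place of methyl on an amine nitrogen in a ring, and phenylsulfonyl in place of methyl on an amine nitrogen in a ring counts that change. Within the data shown here, the one measured step, a 1.5-fold higher number from compound 1 to compound 2 (0.19 log units; within the scatter), lies at another place and says little here. Compound 3 at 8500 nM alone has a sulfonyl group on that nitrogen, yet it differs elsewhere too. A higher number is therefore expected, an estimated 2.1-fold higher number from compound 1 to compound 4 (0.31 log units; beyond the scatter) in all. For compound 4 the estimate is 6000 nM with an expected range from 2500 nM to 15000 nM overall.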

Compound 4, half-maximal inhibitory concentration: 6240 nM
Compound 4: the middle estimate sits 1.0-fold (0.02 log units) below what was measured; measured number inside the range.
By their numbers in this assay, from the lowest: compounds 1, 2, 4 and 3 (each within the scatter of the next, the first and the last beyond it).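

Phenylsulfonyl in place of methyl on the amine nitrogen in the ring is the first change at this position that can be read alone, and in this assay it gives a 2.1-fold higher number from compound 1 to compound 4 (0.33 log units; beyond the scatter) as a modest step. This position therefore carries the much larger phenylsulfonyl group with only that small loss in the number. Nothing shown here accounts for the step. Compound 3 differs from compound 4 in more than one place, so it cannot isolate any effect at this nitrogen. On these data alone, how a benzyl or acetyl group on this nitrogen would compare remains open.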